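Methylsulfonyl for methoxy on the shared core of compound 1

The source may hold more compounds than are shown below. What is called first, only, known or untested is meant among the compounds shown, and "the series" means these compounds.

Among the compounds with values here, compound 1 `COc1ccc(COCC(Cn2ccnc2)OCc2ccc(OC)cc2)cc1` gives 9900 nM in a functional assay for inhibition of Thromboxane-A synthase (Homo sapiens) (on this read-out higher numbers stand for weaker inhibition and lower numbers for stronger inhibition), the highest of the two numbers measured so far. The nearest measured point is compound 2 `COc1ccc(COCC(Cn2ccnc2)OCc2ccc(C(=O)N(C)C)cc2)cc1`, which in this assay gives 1940 nM. Within the data shown here, the single measured step between them, a 5.1-fold lower number from compound 1 to compound 2 (0.71 log units; beyond the scatter), is the only step that bears on the change considered here.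

Compound 3 `COc1ccc(COCC(Cn2ccnc2)OCc2ccc(S(C)(=O)=O)cc2)cc1` differs from compound 1 by methylsulfonyl in place of methoxy on an aromatic carbon. Like the measured step, this change removes the same methoxy on an aromatic carbon and puts a larger group with two double bonds outside aromatic rings in its place, so the measured step is the closest guide available. Among the measured compounds shown here, no measured step shows a methylsulfonyl group anywhere, so the size of the change is taken as uncertain and placed somewhat below the measured one.

The step from compound 1 to compound 3 is expected to read a 3.3-fold lower number from compound 1 to compound 3 (0.52 log units; beyond the scatter) in this assay. Compound 3 is accordingly estimated at 3000 nM in this assay, with a range from 1200 nM to 8000 nM.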

Compound 3, half-maximal inhibitory concentration: 24900 nM
Compound 3: the middle estimate sits 8.3-fold (0.92 log units) below what was measured; the measured number lies above the stated range.
By their numbers in this assay, from the lowest: compound 2; then compound 1; then compound 3.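

In this assay the position para to a large group does not answer in one direction to every replacement of methoxy: methylsulfonyl gives a 2.5-fold higher number from compound 1 to compound 3 (0.40 log units; beyond the scatter) and so runs against the fall seen with dimethylcarbamoyl in compound 2. Within the data shown here, both replacements remove the same methoxy and bring in a larger group, yet the two entering groups themselves are separated by a 13-fold higher number from compound 2 to compound 3 (1.11 log units; beyond the scatter) and this is the largest step so far, which shows that the read-out at this place depends strongly on which group enters and not only on the loss of methoxy. Nothing at hand accounts for the opposite directions of these two replacements.

Open, going by these compounds, is how far the lower numbers extend among other carbonyl-bearing groups at this place, such as a carboxylic acid, a primary amide or a ketone, and whether an amine or a longer chain follows compound 2 or compound 3. Also open, on these data alone, is whether the same replacements read alike at the other methoxy of the shared core.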